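The source may report more compounds than this note shows. Statements on the series, on what has been measured and on what is new or still open speak of the compounds shown alone.

Of the compounds shown here, two have numbers so far in a physicochemical assay for solubility, read by LC-MS, in phosphate buffer, at pH 6.5, tested at 50 uM; a lower number here means a less soluble compound, a higher number a more soluble compound. Compound 1 (`Cc1nc(C)c(C(=O)Nc2ccc(F)c(-c3nc4ncc(-c5cccnc5Cl)cn4n3)c2)o1`) gives 2590 nM, the lower of the two. Compound 2 (`O=C(Nc1ccc(F)c(-c2nc3ncc(-c4cccnc4F)cc3[nH]2)c1)N1CCCC1`) gives 5900 nM, and the gap between them lies beyond the usual scatter of repeated measurements. The two structures differ in more than one place, so this gap cannot be tied to any single group.

Compound 3 (`Cc1nc(C)c(C(=O)Nc2ccc(F)c(-c3nc4ncc(-c5ccccc5Cl)cn4n3)c2)o1`) has not yet been measured. It departs from compound 1 in one group, on an aromatic carbon of a six-membered aromatic ring with 2 nitrogen, part of a fused or bridged system of two rings: 2-chlorophenyl in place of 2-chloropyridin-3-yl (2-chlorophenyl in place of 2-chloropyridin-3-yl on an aromatic carbon). The entering ring is of carbon only. Among the compounds with values here, no measured pair shows this exchange, so the expectation rests on the structural change alone. A modest fall is expected in this assay, an estimated step of a 2.2-fold lower number from compound 1 to compound 3 (0.33 log units; beyond the scatter), only slightly beyond the scatter. For compound 3 the expected solubility is 1200 nM, with an estimated range of 400 nM to 3000 nM.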

Compound 3, solubility: 2400 nM
Estimate against measurement, compound 3: 2.0-fold (0.30 log units) below; measured number inside the range.
By their numbers in this assay, from the lowest: compounds 3 and 1 (each within the scatter of the next); then compound 2.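

On an aromatic carbon of the shared core, two atoms from the ring nitrogen, 2-chlorophenyl in place of 2-chloropyridin-3-yl gives a 1.1-fold lower number from compound 1 to compound 3 (0.03 log units; within the scatter) in this assay. Within the data shown here, this is the first comparison here that can be tied to a single place, which the earlier pair of compounds could not offer. It shows that, with the rest of compound 1 held fixed, a ring of carbon only can stand where the pyridine stood, and that losing the nitrogen and the hydrogen-bond acceptor of the leaving group leaves the two numbers within the scatter of each other, though nothing measured here accounts for that result.

Going by these compounds, this is one pair on one structure, so whether the exchange behaves the same way on the different structure of compound 2 remains open. Also open, on these data alone, is how this assay would respond to a group of another kind at this place, such as a ring bearing an amine or a carboxylic acid, or a morpholine in place of the 2-chlorophenyl.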